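A few compounds are considered here, and "the series" means these few. Any claim that something is new, unique, unknown or untested is made for them only; others in the source may bear on it.

Compound 1 `COC(=O)c1sc2cc(C#Cc3cccc(N)c3)cnc2c1N`: 11500 nM
Compound 2 `COC(=O)c1sc2cc(C#Cc3ccccc3OC)cnc2c1N`: > 47300 nM

In a functional assay on NCI-H460 cells (Homo sapiens) for inhibition, read by sulforhodamine B assay, with a stated time of 48 h (a lower number here means a stronger inhibitor of growth, a higher number a weaker inhibitor of growth), compound 1 gives 11500 nM. In this assay compound 2 reaches only a limit, > 47300 nM, so its standing is known solely as a bound (the limit of > 47300 nM in this assay, at which 1 of the 2 values shown sits). Compound 3 `COC(=O)c1sc2cc(C#Cc3cccc(OC)c3)cnc2c1N` differs from compound 2 by 3-methoxyphenyl in place of 2-methoxyphenyl on a triple-bonded carbon. For the measured compounds named here, the one measured step that bears on this, an at least 4.1-fold higher number from compound 1 to compound 2 (0.61 log units; beyond the scatter), shows the 2-methoxyphenyl compound weaker than the 3-aminophenyl one, and only as a limit. For compound 3 the expected step is an at least 1.5-fold lower number from compound 2 to compound 3 (0.19 log units; that floor lies within the scatter), toward a lower number. Compound 3 is therefore estimated at 30000 nM, within 10000 nM to 90000 nM.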

Compound 3, concentration for 50% growth inhibition: 49000 nM
The estimate for compound 3 lay 1.6-fold (0.21 log units) below the measured number, and the stated range covers the measured number.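

In this assay, methoxy in place of amino on an aromatic carbon gives a 4.3-fold higher number from compound 1 to compound 3 (0.63 log units; beyond the scatter). For the compounds shown here, this is the first measured step that changes the group alone, since the earlier step changed both the group and where it sits on the phenyl ring. The step from compound 2 to compound 3 cannot be read, so what moving the methoxy does stays unknown: the limit of > 47300 nM in this assay, at which 1 of the 3 values shown sits.

As far as these compounds go, whether a 3-hydroxyphenyl or 3-dimethylaminophenyl group on the triple-bonded carbon would give a number nearer that of compound 1 or that of compound 3 stays open.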